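A few compounds are considered here, and "the series" means these few. Any claim that something is new, unique, unknown or untested is made for them only; others in the source may bear on it.

Compound 2 `COc1cncc(-c2c(C)nn(-c3nc(-c4ccc(Cl)c(Cl)c4)c(SC(C)C)s3)c2C(=O)O)c1` is the point of departure. In a functional assay on BJAB cells (Homo sapiens) for antiproliferative activity, with a stated time of 4 days (a higher number here means that more compound is needed for the effect, a lower number that less compound is needed), compound 2 gives 21000 nM. Among the three measured compounds, its number is matched within the scatter by compound 1 `Cc1nn(-c2nc(-c3ccc(Cl)c(Cl)c3)c(SC(C)C)s2)c(C(=O)O)c1Cc1ccccc1[N+](=O)[O-]`, which gives 20000 nM, and it lies beyond the scatter from compound 3 `Cc1c(-c2cc(Cl)cc(Cl)c2)c(C(=O)O)nn1-c1nc(-c2cc(Cl)cc(Cl)c2)c(SC(C)C)s1`, which gives 2000 nM. Within the data shown here, the one measured step with a single change, a 1.1-fold higher number from compound 1 to compound 2 (0.02 log units; within the scatter), exchanged the group on the same aromatic carbon of the shared core and left the number essentially where it was.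

Compound 4 `CCOc1ncccc1-c1c(C)nn(-c2nc(-c3ccc(Cl)c(Cl)c3)c(SC(C)C)s2)c1C(=O)O` differs from compound 2 by 2-ethoxypyridin-3-yl in place of 5-methoxypyridin-3-yl on an aromatic carbon. Among the measured compounds shown here, that step bears on the only measured step at this position, which was within the scatter, so nothing beyond the scatter is expected here either; no measured pair shows an ethoxy group on the pyridine, so the direction is unknown. Compound 4 is therefore expected to give 20000 nM, with a likely range of 7000 nM to 50000 nM. The step from compound 2 to compound 4 is estimated as a 1.1-fold lower number from compound 2 to compound 4 (0.02 log units; within the scatter).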

Compound 4, half-maximal effective concentration: 11000 nM
For compound 4 the middle estimate is 1.8-fold (0.26 log units) above the measured one, within the range that was stated.
By their numbers in this assay, from the lowest: compound 3; then compounds 4, 1 and 2 (each within the scatter of the next).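

In this assay the new group gives a 1.9-fold lower number from compound 2 to compound 4 (0.28 log units; within the scatter) and, set against the 2-nitrobenzyl group, a 1.8-fold lower number from compound 1 to compound 4 (0.26 log units; within the scatter). This adds a second pyridine with a different alkoxy group to the earlier pair, and the numbers of compounds 1, 2 and 4 all remain within the scatter of one another, so three different groups on this aromatic carbon of the shared core are not told apart by this measurement. No measurement offered here accounts for this result.

The change from 5-methoxypyridin-3-yl to 2-ethoxypyridin-3-yl alters both the alkoxy chain and where it sits on the pyridine, and these two changes cannot be separated here. Going by these compounds, it remains open whether an amine or a longer chain on this pyridine would move the number beyond the scatter.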